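A Branched Chain Tried on Two Related Cores

This account rests on a few compounds, and the source may have more. Where it says the series, first, only, none or still open, it means among the compounds named here.

Three measured compounds share most of their structure and were tested in a functional assay on CHO cells for positive allosteric modulation of metabotropic glutamate receptor 2 (Homo sapiens), read by scintillation counting and GTPgammaS binding, with a stated time of 30 min; a lower number here means that less compound is needed, a higher number that more compound is needed for the effect. Compound 2 `CCCCn1ccc(-c2ccc(Oc3ccnc(C)c3)cc2)c(C#N)c1=O` gives 398 nM in this assay. Compound 1 `Cc1cc(Oc2ccc(-c3ccn(CCC(C)C)c(=O)c3C#N)cc2)ccn1` differs from compound 2 in one place, (methyl in place of hydrogen on a saturated chain carbon bound to two saturated chain carbons), and compound 1 gives 447 nM; that step is a 1.1-fold higher number from compound 2 to compound 1 (0.05 log units; within the scatter). Compound 3 `CCCCn1ccc(-c2ccc(Oc3cccnc3C)cc2)c(C#N)c1=O` carries a different core, and the difference between the two cores is 2-methylpyridin-3-yl in place of 2-methylpyridin-4-yl on an oxygen on an aromatic ring. In this assay compound 3 gives 347 nM, and the step is a 1.1-fold lower number from compound 2 to compound 3 (0.06 log units; within the scatter).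

Compound 4 `Cc1ncccc1Oc1ccc(-c2ccn(CCC(C)C)c(=O)c2C#N)cc1` has not yet been measured. It differs from compound 3 by methyl in place of hydrogen on a saturated chain carbon bound to two saturated chain carbons, which is the same change that turns compound 2 into compound 1, now made on the core of compound 3; among these compounds it occurs twice, and the place is described in the same words both times. The expected step is a 1.1-fold higher number from compound 3 to compound 4 (0.04 log units; within the scatter), which rests on the earlier 1.1-fold higher number from compound 2 to compound 1 (0.05 log units; within the scatter), a step that stayed within the scatter. Compound 4 is therefore estimated at 380 nM in this assay. For compound 4 the likely range is expected to run from 200 nM to 720 nM.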

Compound 4, half-maximal effective concentration: 275 nM
The estimate for compound 4 lay 1.4-fold (0.14 log units) above the measured number; low and high end bracket the measured number.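

In this assay, the methyl that turns butyl into isopentyl comes with a 1.3-fold lower number from compound 3 to compound 4 (0.10 log units; within the scatter), and the change from 2-methylpyridin-4-yl to 2-methylpyridin-3-yl comes with a 1.6-fold lower number from compound 1 to compound 4 (0.21 log units; within the scatter). Within the scatter, the chain change reads alike on the two cores: the same change on two cores in this assay, a 1.1-fold higher number (0.05 log units; within the scatter) from compound 2 to compound 1 and a 1.3-fold lower number (0.10 log units; within the scatter) from compound 3 to compound 4, 1.4-fold (0.15 log units) apart, within the scatter of two such steps Neither change is shown to do anything by itself, and two cores are too few to say that either change would carry over in the same way to a further core, while the pyridine change also reads alike on these two: the same change on two cores in this assay, a 1.1-fold lower number (0.06 log units; within the scatter) from compound 2 to compound 3 and a 1.6-fold lower number (0.21 log units; within the scatter) from compound 1 to compound 4, 1.4-fold (0.15 log units) apart, within the scatter of two such steps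

The compounds shown leave open whether a longer chain such as hexyl, or a chain ending in an amine or a carboxylic acid, would give a number beyond the scatter of these four. They also leave open whether the same two changes would read alike on a core without the nitrile.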